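This account rests on a few compounds, and the source may have more. Where it says the series, first, only, none or still open, it means among the compounds named here.

In an assay on HEK293 cells for agonist activity at transient receptor potential cation channel subfamily M member 8 (Homo sapiens), read by fluorescence and calcium flux, with a stated time of 15 min (on this read-out lower numbers stand for an effect already at smaller amounts and higher numbers for an effect only at larger amounts of compound), compound 1, `Cc1ccc(OCC(=O)N(Cc2cccs2)c2ccccc2)cc1`, gives 23 nM, and compound 2, `C=CCN(Cc1cccs1)C(=O)COc1ccc(C)cc1`, gives 20 nM. For the measured compounds named here, the one measured step, a 1.2-fold lower number from compound 1 to compound 2 (0.06 log units; within the scatter), shows that swapping the group on the amide-type nitrogen between phenyl and allyl leaves the number essentially unchanged, so compound 2 stands within the scatter of compound 1 and is not distinguishable from it on these two numbers. Compound 3, `Cc1ccc(OCC(=O)N(Cc2cccs2)c2ccn[nH]2)cc1`, takes the same place a step further: 1H-pyrazol-5-yl in place of allyl on an amide-type nitrogen. The measured step bears on it only loosely, since it compared two groups without hydrogen-bond donors or acceptors, while the incoming group carries one of each on an aromatic ring. For compound 3 the step of a 3.0-fold higher number from compound 2 to compound 3 (0.48 log units; beyond the scatter) is therefore expected to lean towards a higher number, with wide uncertainty. Compound 3 is estimated at 60 nM, within a range of 15 nM to 300 nM.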

Compound 3, half-maximal effective concentration: 0.2 nM
Estimate against measurement, compound 3: 300-fold (2.48 log units) above; the whole stated range lies above it.
By their numbers in this assay, from the lowest: compound 3; then compounds 2 and 1 (each within the scatter of the next).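

On the amide-type nitrogen, the phenyl and allyl pair had given no sign that this position matters, but in this assay the 1H-pyrazol-5-yl group brings a 100-fold lower number from compound 2 to compound 3 (2.00 log units; beyond the scatter) and a 120-fold lower number from compound 1 to compound 3 (2.06 log units; beyond the scatter) on the same nitrogen. The position therefore responds strongly to the group placed on it, and the two earlier groups, which lie within the scatter of each other, do not show the span of numbers it can reach. Nothing available here accounts for the large difference between the 1H-pyrazol-5-yl group and the two earlier groups. Going by these compounds, whether an imidazole, a pyridine or a pyrazole carrying a methyl group on its ring nitrogen would give a number close to that of compound 3 on this nitrogen remains open. So does whether the same large step would appear with other groups elsewhere on the shared core.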